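Shortening the branched side chain on a shared core

The source may hold more compounds than are shown below. What is called first, only, known or untested is meant among the compounds shown, and "the series" means these compounds.

Measured compounds:
- Compound 1, `C#CC(=O)N1C(c2ccc(C#N)cc2)SC[C@@H]1C(=O)OCC`, gives 2600 nM in a functional assay on Huh-7 cells (Homo sapiens) for inhibition, read by sulforhodamine B assay; a higher number here means a weaker inhibitor, a lower number a stronger inhibitor.
- Compound 2, `C#CC(=O)N1C(CC(C)CC(C)(C)C)SC[C@@H]1C(=O)OCC`, gives 1600 nM in this assay.

Compound 2 holds the lowest of the two numbers. Its nearest neighbour is compound 1, whose number is higher, but the gap between them lies within the scatter, so neither compound can be called the stronger inhibitor. For the measured compounds named here, no step between the two measured compounds has been worked out, since they differ in more than one place.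

Compound 3, `C#CC(=O)N1C(CCCCC)SC[C@@H]1C(=O)OCC`, has not yet been measured. It differs from compound 2 in a single place: butyl in place of 1,3,3-trimethylbutyl on a saturated chain carbon bound to a saturated ring carbon. The branched chain is replaced by a shorter, unbranched one at the same saturated chain carbon. Going by the values given here, with only two measured values and no isolated step to guide the move, the expected size of the step from compound 2 to compound 3 is small, most likely none beyond the scatter, with a slight lean toward a higher number. Compound 3 is therefore estimated at 2500 nM, in a range from 1000 nM to 7000 nM, which means a step of a 1.6-fold higher number from compound 2 to compound 3 (0.19 log units; within the scatter).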

Compound 3, half-maximal inhibitory concentration: 1800 nM
The estimate for compound 3 lay 1.4-fold (0.14 log units) above the measured number; measured number inside the range.
By their numbers in this assay, from the lowest: compounds 2, 3 and 1 (each within the scatter of the next).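

In this assay, for the compounds shown here, butyl in place of 1,3,3-trimethylbutyl on a saturated chain carbon bound to a saturated ring carbon gives a 1.1-fold higher number from compound 2 to compound 3 (0.05 log units; within the scatter) as the first step that isolates a single place on the shared core. Between these two compounds, then, the shorter, unbranched chain and the longer, branched one cannot be told apart in this read-out, so this change at this position shows no measurable effect on the number. No independent evidence bears on this result.

The compounds shown leave open whether a much shorter group such as methyl, or a chain ending in an amine or a carboxylic acid, would move the number beyond the scatter at this same saturated chain carbon. They also leave open whether a chain longer than 1,3,3-trimethylbutyl would be met with the same lack of response, or whether the tolerance seen between compound 2 and compound 3 has a limit on that side.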